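A few compounds are considered here, and "the series" means these few. Any claim that something is new, unique, unknown or untested is made for them only; others in the source may bear on it.

Compound 2 `N#C/C(=C\c1ccc(O)c(O)c1)C(=O)OCC#Cc1ccsc1` gives 5% in a functional assay on the whole organism (strain CD-1) for inhibition, with Mus musculus as the target, in the writhing test, with stated times of 15 min and 20 min, at a dose of 10 mg/kg by the subcutaneous route (on this read-out higher numbers stand for more inhibition at the one dose given (going by the name of the read-out) and lower numbers for less inhibition), the lowest of the two numbers measured; compound 1 `N#C/C(=C\c1ccc(O)c(O)c1)C(=O)OCC#Cc1ccccc1` gives 22%, so the step of a number 17 percentage points lower from compound 1 to compound 2 (beyond the scatter) shows that changing the ring on the triple-bonded carbon matters. Compound 3 `CCOC(=O)/C(C#N)=C/c1ccc(O)c(O)c1` differs from compound 2 by methyl in place of 2-(thiophen-3-yl)ethynyl on a saturated chain carbon bound to an oxygen next to a carbonyl group. Among the measured compounds shown here, no measured step alters this part of the molecule, so the one known step is only a loose guide; a modest rise is expected. Compound 3 is expected to give 15%, between 0% and 35%. This expectation means a step of a number 10 percentage points higher from compound 2 to compound 3 (within the scatter).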

Compound 3, a percentage reported as inhibition, in the whole organism at one dose (the size of the read-out at that dose, not a potency): 21.8%
Compound 3: the middle estimate sits 6.8 percentage points below what was measured, and the stated range covers the measured number.
By their numbers in this assay, from the lowest: compound 2; then compounds 3 and 1 (each within the scatter of the next).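

Methyl in place of 2-(thiophen-3-yl)ethynyl on this saturated chain carbon gives a number 16.8 percentage points higher from compound 2 to compound 3 (beyond the scatter) in this assay, so the 2-(thiophen-3-yl)ethynyl group is not needed for the inhibition seen with compound 3. Methyl in place of 2-phenylethynyl gives a number 0.2 percentage points lower from compound 1 to compound 3 (within the scatter), so compound 1 and compound 3 cannot be told apart here, even though the group is replaced entirely. Nothing available explains these results. From the compounds shown here alone, it remains open how a propyl chain or a chain ending in an amine would behave at this position, and how the carboxylic acid would compare.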